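Trimethoxyphenyl replacing fluorophenyl on the ketone of compound 3

The source may hold more compounds than are shown below. What is called first, only, known or untested is meant among the compounds shown, and "the series" means these compounds.

Measured compounds:
compound 1 `COc1cc(-c2nnc3n2NC(c2cccs2)C(C(=O)c2ccc(C)cc2)S3)cc(OC)c1OC`: 28400 nM
compound 2 `COc1ccc(C(=O)C2Sc3nnc(-c4cc(OC)c(OC)c(OC)c4)n3NC2c2cccs2)cc1`: 49500 nM
compound 3 `COc1cc(-c2nnc3n2NC(c2ccco2)C(C(=O)c2ccccc2F)S3)cc(OC)c1OC`: 94800 nM

In a functional assay on MCF7 cells (Homo sapiens) for cytotoxicity, read by MTT assay, with a stated time of 48 h (a lower number here means a stronger inhibitor, a higher number a weaker inhibitor), compound 3 gives the highest number of the three measured compounds. Its value stands closest to that of compound 2 and furthest from that of compound 1.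

Compound 4 `COc1cc(C(=O)C2Sc3nnc(-c4cc(OC)c(OC)c(OC)c4)n3NC2c2ccco2)cc(OC)c1OC` is not yet measured. It differs from compound 3 in one place: 3,4,5-trimethoxyphenyl in place of 2-fluorophenyl on a carbonyl carbon. For the measured compounds named here, the only measured step on the ketone aryl group is a 1.7-fold higher number from compound 1 to compound 2 (0.24 log units; within the scatter), which is within the scatter. Going by the values given here, that step concerns the same carbonyl-bearing aryl ring, though the change there is smaller than the one from compound 3 to compound 4, and no measured pair shows the 3,4,5-trimethoxyphenyl group on the carbonyl carbon. On this basis the step of a 1.1-fold higher number from compound 3 to compound 4 (0.02 log units; within the scatter) is expected to stay within the scatter, with no clear direction. Compound 4 is therefore estimated at 100000 nM in this assay, with a range from 40000 nM to 250000 nM.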

Compound 4, half-maximal inhibitory concentration: > 100000 nM
Compound 4: a limit, no number; the forecaster's own chance of this, stated with the estimate: 20%; the middle value sits exactly at the limit.
By their numbers in this assay, from the lowest: compounds 1, 2 and 3 (each within the scatter of the next, the first and the last beyond it). At a limit, above all of these: compound 4.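

In this assay compound 4 gives > 100000 nM, which is a limit of the assay and not a number. For the compounds shown here, this is the first view of the 3,4,5-trimethoxyphenyl group on this carbonyl carbon, and it brings no lower number than 2-fluorophenyl does, with only a floor for the step: an at least 1.0-fold higher number from compound 3 to compound 4 (0.02 log units; that floor lies within the scatter). How far the change raises the number cannot be told: the limit of > 100000 nM in this assay, at which 1 of the 4 values shown sits.

Left open is how an unsubstituted phenyl, or an aryl ring carrying an amine or a carboxylic acid, would read on this carbonyl carbon in this assay. Also open, going by these compounds, is whether the 3,4,5-trimethoxyphenyl group would give a measurable number on the core of compound 1.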